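A few compounds are considered here, and "the series" means these few. Any claim that something is new, unique, unknown or untested is made for them only; others in the source may bear on it.

Of the compounds shown here, three measured so far share one core and differ only in the end group attached through the linking amide. Compound 1 `O=C(Nc1cccc(-n2cc(-c3ccncc3)c(-c3cc(O)cc(Cl)c3)n2)c1)Nc1ccc(Cl)c(Cl)c1` gives 90% in a functional assay on PC-3 cells (Homo sapiens) for inhibition, read by sulforhodamine B assay, with a stated time of 48 h, tested at 0.1 uM; a higher number here means a weaker effect of the compound at the concentration tested, a lower number a stronger effect. Compound 2 `COc1cc(Cl)cc(-c2nn(-c3cccc(NC(=O)Nc4ccc(Cl)c(C(F)(F)F)c4)c3)cc2-c2ccncc2)c1` gives 91% in this assay. Compound 3 `COc1cc(Cl)cc(-c2nn(-c3cccc(NC(=O)Nc4cc(C(F)(F)F)cc(C(F)(F)F)c4)c3)cc2-c2ccncc2)c1` gives 91% in this assay, the same number as compound 2 at the digits shown, and compound 1 sits within the usual scatter of both. At this low test concentration none of the three holds the cells back to any marked degree.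

Compound 4 `COc1cc(Cl)cc(-c2nn(-c3cccc(NC(=O)Nc4cccc(C(F)(F)F)c4)c3)cc2-c2ccncc2)c1` has not yet been tested. It differs from compound 3 in one place: hydrogen in place of trifluoromethyl on an aromatic carbon. Going by the values given here, no measured pair shows what this change does here, and the gaps among compounds 1, 2 and 3 lie within scatter, so they give no direction. Because compound 1 at 90% and compound 2 at 91% sit together with compound 3 despite differing end groups, the step is expected to be a number 1 percentage points lower from compound 3 to compound 4 (within the scatter), within scatter. Compound 4 is therefore estimated at 90% in this assay, between 78% and 100%.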

Compound 4, a percentage reported as activity, at one concentration (the size of the read-out at that concentration, not a potency): 57%
The estimate for compound 4 lay 33 percentage points above the measured number; the measured number lies below the stated range.
By their numbers in this assay, from the lowest: compound 4; then compounds 1, 2 and 3 (each within the scatter of the next).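

Hydrogen in place of trifluoromethyl on an aromatic carbon gives, in this assay, a number 34 percentage points lower from compound 3 to compound 4 (beyond the scatter), so this end ring responds strongly to its substituents, something the closely grouped earlier numbers could not reveal. Hydrogen in place of chloro, at a different carbon of the same ring, gives a number 34 percentage points lower from compound 2 to compound 4 (beyond the scatter), so in both pairs the compound carrying the second group has the weaker effect, and compound 4, with only one trifluoromethyl group on that ring, has the stronger effect. Nothing available explains why either replacement has this effect.

Going by these compounds, it remains open whether a smaller group, such as fluoro or methyl, would keep the stronger effect of compound 4 at these carbons. The compounds shown also leave open what an amine or a carboxylic acid would do there, and what would happen if the remaining trifluoromethyl group were replaced.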